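The source may hold more compounds than are shown below. What is called first, only, known or untested is meant among the compounds shown, and "the series" means these compounds.

The series rests on a shared core, shown for compound 1 as `CC(C)=CCC/C(C)=C/CC/C(C)=C/CC[C@@H]1[C@@]2(C)CCC(=O)C(C)(C)[C@@H]2CC[C@@]1(C)O` and carrying a ketone at one end; in a functional assay on HepG2 cells (Homo sapiens) for cytotoxicity, read by MTT assay, with a stated time of 48 h (a lower number here means a stronger inhibitor, a higher number a weaker inhibitor), compound 1 gives 26600 nM. Compound 2, `CC(C)=CCC/C(C)=C/CC/C(C)=C/CC[C@@H]1[C@@]2(C)CC/C(=N\OCc3cn(-c4cccc(Br)c4)nn3)C(C)(C)[C@@H]2CC[C@@]1(C)O`, replaces that ketone with an oxime ether bearing a triazole and a bromophenyl ring. In this assay compound 2 gives 39800 nM, and the two values of compound 1 and compound 2 fall within the usual scatter of one another, so neither is separated from the other. Compound 3, `CC(C)=CCC/C(C)=C/CC/C(C)=C/CC[C@@H]1[C@@]2(C)CC/C(=N\OCc3cn(-c4cccc(O)c4)nn3)C(C)(C)[C@@H]2CC[C@@]1(C)O`, differs from compound 2 in one place: hydroxy in place of bromo on an aromatic carbon. For the measured compounds named here, no measured pair in this set isolates such a change, so the expectation for compound 3 rests only on the two values at hand, which sit close together. The step from compound 2 to compound 3 is estimated as a 1.1-fold lower number from compound 2 to compound 3 (0.06 log units; within the scatter), not beyond the scatter in either direction. Compound 3 is therefore expected to give about 35000 nM in this assay, within a range from 12000 nM to 100000 nM.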

Compound 3, half-maximal inhibitory concentration: 21200 nM
Beside the measured number, compound 3's estimate is 1.7-fold (0.22 log units) above it; measured number inside the range.
By their numbers in this assay, from the lowest: compounds 3, 1 and 2 (each within the scatter of the next).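

In this assay, hydroxy in place of bromo on an aromatic carbon gives a 1.9-fold lower number from compound 2 to compound 3 (0.27 log units; within the scatter), the only step among the compounds shown that isolates a change in one place. This exchange adds one hydrogen-bond donor and one hydrogen-bond acceptor at a site meta to a large group, yet the two compounds cannot be told apart in this read-out. No measurement available here accounts for the size of this step.

The compounds shown leave open whether an amine, a carboxylic acid or a methoxy group at this position would separate from bromo and hydroxy in this assay. From the compounds shown here alone, it also remains open whether the same exchange would stay within the scatter at another carbon of this six-membered aromatic ring.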